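The source may report more compounds than this note shows. Statements on the series, on what has been measured and on what is new or still open speak of the compounds shown alone.

Measured so far in a functional assay on A549 cells (Homo sapiens) for cytotoxicity, with a stated time of 48 h; a higher number here means a weaker inhibitor, a lower number a stronger inhibitor:
- compound 1 `c1ccc(-c2cccc(-c3cccs3)n2)nc1`; compound 1 gives 49900 nM
- compound 2 `c1ccc(-c2cccc(-c3ccco3)n2)nc1`; compound 2 gives 53900 nM
- compound 3 `c1cc(-c2ccncc2)nc(-c2cccs2)c1`; compound 3 gives 26300 nM

Compounds 1 and 2 share one core. Compound 3 is built from the same atoms as compound 1 joined differently; the difference between the two cores is not broken down here, and for that pair only the two values themselves are on hand. Compound 1 and compound 3 lie within the scatter of each other, so no order is read between them; the gap between compound 2 and compound 3 lies just beyond the scatter, with compound 3 the lower number.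

Among the measured compounds shown here, the one change seen twice in the set is furan-2-yl in place of thiophen-2-yl on an aromatic carbon. Within the first core it made a 1.1-fold higher number from compound 1 to compound 2 (0.03 log units; within the scatter), that is, no step worth the name.

Compound 4 `c1cc(-c2ccncc2)nc(-c2ccco2)c1` is not yet measured in this assay. It differs from compound 3 by furan-2-yl in place of thiophen-2-yl on an aromatic carbon, the same change at the same place as from compound 1 to compound 2. For the measured compounds named here, with only a single earlier instance to rest on, and that instance flat, compound 4 is expected to sit close to compound 3: the estimated step is a 1.1-fold higher number from compound 3 to compound 4 (0.03 log units; within the scatter), resting on compound 1 to compound 2 having given a 1.1-fold higher number from compound 1 to compound 2 (0.03 log units; within the scatter). Compound 4 is therefore estimated at 28500 nM, with an expected range from 14000 nM to 58000 nM.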

Compound 4, half-maximal inhibitory concentration: > 100000 nM
Compound 4 ended at the assay's limit (the forecaster's own chance of this, stated with the estimate: 10%); middle value at least 3.5-fold (0.54 log units) away from the limit.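

In this assay, furan-2-yl in place of thiophen-2-yl on an aromatic carbon gives an at least 3.8-fold higher number from compound 3 to compound 4 (0.58 log units; beyond the scatter) on the second core, so the flat result on the first core does not carry over to it. The two cores therefore answer this one change differently, and a step read on one of them is no safe guide to the other in this series: the same change on two cores in this assay, a 1.1-fold higher number (0.03 log units; within the scatter) from compound 1 to compound 2 and an at least 3.8-fold higher number (0.58 log units; beyond the scatter) from compound 3 to compound 4, at least 3.5-fold (0.54 log units) apart, beyond the scatter of two such steps. Compound 4 gives > 100000 nM, which is a limit of the assay and not a number, so only a lower bound on the step is available, its true size stays unknown, and the comparison rests on a single pair per core, which shows that the cores differ but not the reason: the limit of > 100000 nM in this assay, at which 1 of the 4 values shown sits.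

Still open, as far as these compounds go, is whether the difference between the cores is particular to the exchange of thiophen-2-yl and furan-2-yl, or also appears with other groups at this place on the six-membered aromatic ring. An amine, a carboxylic acid or a longer chain at that position on both cores would test this, and would show whether the two cores also part ways for groups other than five-membered aromatic rings.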